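The source may report more compounds than this note shows. Statements on the series, on what has been measured and on what is new or still open speak of the compounds shown alone.

Measured compounds in an assay on isolated protein for inhibition of Dipeptidyl peptidase 9 (Homo sapiens), read by fluorescence, with stated times of 15 min and 20 min; on this read-out higher numbers stand for weaker inhibition and lower numbers for stronger inhibition: compound 1, `CC#CCn1c(N2CCC[C@@H](N)C2)cc(=O)n(Cc2cccc(C(=O)O)c2Br)c1=O`, with "not determined" (no result reported); compound 2, `CC#CCn1c(N2CCC[C@@H](N)C2)cc(=O)n(Cc2cccc(C(=O)OC)c2Br)c1=O`, with > 100 nM.

Compound 1 stands on no number in this assay, as its result was not determined. Compound 2 carries the methyl ester in place of the free acid of compound 1; in this assay compound 2 gives only a limit, > 100 nM, so that no single potency can be placed on it; this is the limit named in the limit of > 100 nM in this assay, at which 1 of the 2 values shown sits, and one of the two values shown sits at it.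

Compound 3, `CC#CCn1c(N2CCC[C@@H](N)C2)cc(=O)n(Cc2cc(Br)cc(C(=O)O)c2)c1=O`, differs from compound 1 in that (3-bromo-5-carboxyphenyl in place of 2-bromo-3-carboxyphenyl on a saturated chain carbon bound to an aromatic nitrogen). Going by the values given here, no step between measured compounds is given for this change, and compound 1 itself has no value, so the size and direction of the step in this assay cannot be read from the data; the only anchor is the limit given by compound 2. With one related compound sitting at a limit, compound 3 is expected to be a weak inhibitor as well, and its value in this assay is estimated at 400 nM, within a range from 40 nM to 4000 nM.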

Compound 3, half-maximal inhibitory concentration: > 100 nM
Compound 3: no number, only a limit; the forecaster's own chance of this, stated with the estimate: 55%; the middle value is on the limit's open side.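

Compound 3 gives only a limit in this assay, > 100 nM, and compound 1 has no number there, so no new step can be read between compound 1 and compound 3. The compounds shown leave open whether 2-bromo-3-carboxyphenyl and 3-bromo-5-carboxyphenyl differ at all in this assay, and how far compound 2 and compound 3 lie beyond their shared limit: the limit of > 100 nM in this assay, at which 2 of the 3 values shown sit.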